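The source may report more compounds than this note shows. Statements on the series, on what has been measured and on what is new or still open speak of the compounds shown alone.

Measured so far in a functional assay on B16-F10 cells (Mus musculus) for antiproliferative activity, read by MTT assay, with a stated time of 48 h; a lower number here means a stronger inhibitor, a higher number a weaker inhibitor:

Compound 1 `COc1ccc(/C=C/c2cc(OC)cc(OC)c2/C=C/C(=O)c2ccc(Cl)c(Cl)c2)cc1` gives 7.5 ug/mL
Compound 2 `COc1ccc(/C=C/c2cc(OC)cc(OC)c2/C=C/C(=O)c2cccc(OC)c2)cc1` gives 4.3 ug/mL
Compound 3 `COc1ccc(/C=C/c2cc(OC)cc(OC)c2/C=C/C(=O)c2ccc(C(F)(F)F)cc2)cc1` gives 4.3 ug/mL

Compound 3 stands level with compound 2 (no change at the digits printed from compound 2 to compound 3 (within the scatter)), and its gap to compound 1 is also small (a 1.7-fold lower number from compound 1 to compound 3 (0.24 log units; within the scatter)). The third measured step (a 1.7-fold lower number from compound 1 to compound 2 (0.24 log units; within the scatter)) lies within the scatter too, so these numbers do not separate the three compounds in this assay at all.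

Compound 4 `COc1ccc(/C=C/c2cc(OC)cc(OC)c2/C=C/C(=O)c2ccc(F)cc2)cc1` keeps the core of compound 3 and carries fluoro in place of trifluoromethyl on an aromatic carbon, so that 4-(trifluoromethyl)phenyl becomes 4-fluorophenyl. For the measured compounds named here, no measured pair makes this exact exchange. The nearest evidence is the three steps above, each of which swaps the phenyl group on a carbonyl carbon. Exchanges at this place have so far stayed within the scatter, as compound 3 shows in its step from compound 1 (a 1.7-fold lower number from compound 1 to compound 3 (0.24 log units; within the scatter)), so no step beyond the scatter is expected in either direction. The estimated step is a 1.2-fold higher number from compound 3 to compound 4 (0.07 log units; within the scatter) and it is expected to stay within the scatter. The estimated value in this assay for compound 4 is 5 ug/mL (expected range 2.5 ug/mL to 10 ug/mL).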

Compound 4, half-maximal inhibitory concentration: 5.3 ug/mL
Estimate against measurement, compound 4: 1.1-fold (0.03 log units) below; measured number inside the range.
By their numbers in this assay, from the lowest: compounds 2, 3, 4 and 1 (each within the scatter of the next).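

In this assay, for the compounds shown here, the exchange of trifluoromethyl for fluoro on an aromatic carbon para to a large group gives a 1.2-fold higher number from compound 3 to compound 4 (0.09 log units; within the scatter), which is the first direct reading of a change to the substituent alone, with the rest of compound 3 left intact. The other two new steps agree with it: the change of the whole aryl group gives a 1.2-fold higher number from compound 2 to compound 4 (0.09 log units; within the scatter) and also a 1.4-fold lower number from compound 1 to compound 4 (0.15 log units; within the scatter), so 4-fluorophenyl cannot be told apart from 3-methoxyphenyl, 3,4-dichlorophenyl or 4-(trifluoromethyl)phenyl on the carbonyl carbon, and all four compounds remain unseparated in this assay. Nothing available bears on why these exchanges leave the number within the scatter.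

On these data alone, the four compounds carry only halogen, trifluoromethyl or methoxy substituents on this phenyl ring, so it remains open whether an amine or a carboxylic acid at this position would produce a step beyond the scatter. As far as these compounds go, since the rest of the structure is the same in all four compounds, it also remains open how far the number depends on the methoxy groups or the two carbon-carbon double bonds of the shared core.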